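Estimating compound 4 from three measured compounds

The source may hold more compounds than are shown below. What is called first, only, known or untested is meant among the compounds shown, and "the series" means these compounds.

Measured in a functional assay on HCT-116 cells (Homo sapiens) for inhibition, read by MTT assay, with a stated time of 48 h (on this read-out higher numbers stand for weaker inhibition and lower numbers for stronger inhibition), as follows

Compound 1 `COc1ccc(N(C)c2nc(C)nc3ccccc23)cc1OCCC[Se]C#N` gives 852 nM
Compound 2 `COc1ccc(N(C)c2nc(C)nc3ccccc23)cc1C(=O)OCCC[Se]C#N` gives 720 nM
Compound 3 `COc1ccc(N(C)c2nc(C)nc3ccccc23)cc1[Se]C` gives 28 nM

Compound 3 stands lowest of the three at 28 nM in this assay with its steps to both others beyond the scatter. Compound 4 `COc1ccc(N(C)c2nc(C)nc3ccccc23)cc1C(=O)OCCCC[Se]C#N` carries a group of 10 heavy atoms (6 carbon, 1 nitrogen, 2 oxygen, 1 selenium; no ring) in place of a group of 2 heavy atoms (1 carbon, 1 selenium; no ring), on an aromatic carbon at the place ortho to a methoxy group. Two large steps bear on this: a 30-fold lower number from compound 1 to compound 3 (1.48 log units; beyond the scatter) and a 26-fold lower number from compound 2 to compound 3 (1.41 log units; beyond the scatter) each came with the small group replacing a longer one, whereas a 1.2-fold lower number from compound 1 to compound 2 (0.07 log units; within the scatter) stayed within the scatter. In this group compound 4 resembles compound 2 at 720 nM so a large step to a higher number is expected in this assay from this change. The expected step is a 25-fold higher number from compound 3 to compound 4 (1.40 log units; beyond the scatter) on this estimate. Compound 4 is estimated at 700 nM with 250 nM to 1800 nM as its range.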

Compound 4, half-maximal inhibitory concentration: 662 nM
Compound 4: the middle estimate sits 1.1-fold (0.02 log units) above what was measured; the range from low to high includes it.
By their numbers in this assay, from the lowest: compound 3; then compounds 4, 2 and 1 (each within the scatter of the next).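

In this assay, lengthening the ester chain made no difference that can be told apart, with a 1.1-fold lower number from compound 2 to compound 4 (0.04 log units; within the scatter), and the change from the shorter ether-linked chain also stayed small, with a 1.3-fold lower number from compound 1 to compound 4 (0.11 log units; within the scatter). The large gap from the small selenium-bearing group held for this third long group, with a 24-fold higher number from compound 3 to compound 4 (1.37 log units; beyond the scatter), so at this place the number did not respond to chain length across the long groups shown. Nothing measured here gives a reason for this. Still open, on these data alone, is whether a much longer chain would stay at this level, and whether an amine or a carboxylic acid in place of the terminal nitrile would bring the number nearer to that of compound 3.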